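Butyl to cyclopentyl on sulfur: notes on tolerated concentration

The source may report more compounds than this note shows. Statements on the series, on what has been measured and on what is new or still open speak of the compounds shown alone.

Compound 3 (`CCCCSc1nc(C(C)c2c(F)cccc2Cl)cc(=O)[nH]1`) has no numerical reading to start from. In an ADME assay on MT4 cells (Homo sapiens) for activation, read by MTT assay (a higher number here means that more compound is tolerated, a lower number that less compound is tolerated), compound 3 gives > 73000 nM, which is a limit of the assay and not a number. Compound 2 (`CCC(C)Sc1nc(C(C)c2c(F)cccc2Cl)cc(=O)[nH]1`) shares the core of compound 3 but carries sec-butyl on the sulfur. In this assay compound 2 gives > 73000 nM, again a limit.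

The next change leads to compound 4 (`CC(c1cc(=O)[nH]c(SC2CCCC2)n1)c1c(F)cccc1Cl`), with cyclopentyl in place of butyl on a sulfur. Within the data shown here, the one measured step that bears on this place is a step that the two limits leave unreadable from compound 2 to compound 3, with butyl in place of sec-butyl on a sulfur. That step offers no size to carry over.

The nearest guide is compound 1 (`O=c1cc(Cc2c(F)cccc2Cl)nc(SC2CCCC2)[nH]1`), which also has cyclopentyl on a sulfur. In this assay compound 1 gives > 74000 nM, also a limit. Given that reading for compound 1, no step beyond the scatter is expected in this assay, and compound 4 will most likely be reported as a limit too. The estimated step is an at least 1.0-fold lower number from compound 3 to compound 4 (0.01 log units; that floor lies within the scatter). The estimated value for compound 4 is 71000 nM, with an expected range from 30000 nM to 80000 nM.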

Compound 4, half-maximal cytotoxic concentration: > 71000 nM
Compound 4 ended at the assay's limit; the forecaster's own chance of this, stated with the estimate: 80%; the middle value lies on the limit itself.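

In this assay compound 4 gives > 71000 nM, a limit of the assay and not a number. Its steps from compound 1, compound 2 and compound 3 cannot be read. The compounds shown leave open whether either the group on the sulfur or the methyl in place of hydrogen changes the tolerated concentration at all.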